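The compounds below may be only part of what the source reports. "The series", "measured", "known", "first", "only" and "open" are said of these compounds alone.

Compound 1 `COc1cc2c(Oc3ccc(NC(=O)c4nn(-c5ccccc5)c(=O)cc4C)cc3F)ccnc2cc1OCCCN1CCCC1` is measured in a functional assay on MKN-45 cells (Homo sapiens) for inhibition, read by MTT assay, with a stated time of 72 h (on this read-out lower numbers stand for stronger inhibition and higher numbers for weaker inhibition), where compound 1 gives 120 nM. Two companions share its core and differ only in the amine at the end of the chain: compound 2 `COc1cc2c(Oc3ccc(NC(=O)c4nn(-c5ccccc5)c(=O)cc4C)cc3F)ccnc2cc1OCCCN1CCCCC1` gives 160 nM, and compound 3 `COc1cc2c(Oc3ccc(NC(=O)c4nn(-c5ccccc5)c(=O)cc4C)cc3F)ccnc2cc1OCCCN1CCN(C)CC1` gives 130 nM. Of the three numbers, compound 1 has the lowest, but the steps of a 1.3-fold higher number from compound 1 to compound 2 (0.12 log units; within the scatter) and a 1.1-fold higher number from compound 1 to compound 3 (0.03 log units; within the scatter) are both within the scatter, as is a 1.2-fold lower number from compound 2 to compound 3 (0.09 log units; within the scatter), so the three compounds cannot be told apart on this read-out.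

Compound 4 `COc1cc2c(Oc3ccc(NC(=O)c4nn(-c5ccccc5C)c(=O)cc4C)cc3F)ccnc2cc1OCCCN1CCCC1` comes from compound 1 by a change elsewhere: methyl in place of hydrogen on an aromatic carbon, on an aromatic carbon of a six-membered aromatic ring of carbon only, ortho to a large group. Among the compounds with values here, none of the measured steps touches this ring; they all concern the amine on the chain, so no measured step bears on this change. With nothing to point either way, the step of a 1.1-fold higher number from compound 1 to compound 4 (0.03 log units; within the scatter) is expected to stay within the scatter. Compound 4 is therefore estimated at 130 nM, with a range from 40 nM to 450 nM.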

Compound 4, half-maximal inhibitory concentration: 760 nM
Compound 4: middle estimate off by 5.8-fold (0.77 log units), on the low side; the measured number lies above the stated range.
By their numbers in this assay, from the lowest: compounds 1, 3 and 2 (each within the scatter of the next); then compound 4.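

The earlier compounds shown here differed only in the amine at the end of the chain, and in this assay those changes could not be told apart. The phenyl ring is different: adding just one heavy atom, a methyl on an aromatic carbon ortho to a large group, gives a 6.3-fold higher number from compound 1 to compound 4 (0.80 log units; beyond the scatter), a step beyond the scatter towards weaker inhibition. So this position responds to a small change in a way the chain amines never did, though nothing at hand explains why.

The compounds shown leave open whether this loss is specific to methyl or would also follow from a fluorine, a chlorine or a methoxy on the same carbon. Going by these compounds, it is also open whether a methyl on another carbon of this ring would give a similar step.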